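A few compounds are considered here, and "the series" means these few. Any claim that something is new, unique, unknown or untested is made for them only; others in the source may bear on it.

Measured so far in a functional assay on DLD-1 cells (Homo sapiens) for antiproliferative activity, read by CellTiter-Glo, with a stated time of 72 h; on this read-out lower numbers stand for stronger inhibition and higher numbers for weaker inhibition:
- compound 1 `CC1CCN(C2CCN(S(=O)(=O)c3cccnc3Cl)CC2)CC1` gives > 5000 nM, which is a limit of the assay and not a number.
- compound 2 `Cc1cc(C)c(S(=O)(=O)NCCN2CCC(C)CC2)c(C)c1` gives 1900 nM.

For the measured compounds named here, compound 1 stands only at the limit (the limit of > 5000 nM in this assay, at which 1 of the 2 values shown sits); no number is known for it, and compound 2 is the only compound of the pair with a measured value in this assay. Going by the values given here, no step between two measured compounds is available, so how strongly this series responds to a change at the sulfonyl sulfur is not yet known from the data.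

Compound 3 `CC1CCN(C2CCN(S(=O)(=O)c3cccc(Cl)c3)CC2)CC1` is still to be measured. It differs from compound 1 by 3-chlorophenyl in place of 2-chloropyridin-3-yl on a sulfonyl sulfur. With compound 1 sitting at the limit in this assay, the size of the step cannot be anchored in a measured number; a step within the usual scatter is expected, and a fair chance remains that compound 3 also returns only a limit.

Compound 3 is therefore expected to give about 6000 nM in this assay, in the range 2000 nM to 20000 nM. The expected step is a step that the limit leaves unreadable from compound 1 to compound 3.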

Compound 3, half-maximal inhibitory concentration: > 5000 nM
Compound 3 gave a limit, no number; the forecaster's own chance of this, stated with the estimate: 60%; the middle value is on the limit's open side.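

In this assay compound 3 gives > 5000 nM, a limit and not a number, so no step from compound 1 to compound 3 can be read: the limit of > 5000 nM in this assay, at which 2 of the 3 values shown sit.

The compounds shown leave open how far 3-chlorophenyl in place of 2-chloropyridin-3-yl on a sulfonyl sulfur changes antiproliferative activity in this series.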